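Replacing the Cyano Group of Compound 2 With Methyl

The compounds below may be only part of what the source reports. "The series", "measured", "known", "first", "only" and "open" are said of these compounds alone.

For the measured compounds named here, in an ADME assay on the whole organism for pharmacokinetics, with Mus musculus as the target, at a dose of 10 mg/kg by the oral route (a lower number here means less compound in the circulation, a higher number more compound in the circulation at the dose given), compound 1 `CC/C(=C(/c1ccc(/C=C/C(=O)O)cc1)c1ccc2[nH]ncc2c1)c1ccccc1` gives 5800 ng.h/mL and compound 2 `CC/C(=C(/c1ccc(/C=C/C(=O)O)cc1)c1ccc2[nH]ncc2c1)c1ccccc1C#N` gives 200 ng.h/mL, so compound 2 holds the lower of the two numbers so far. Going by the values given here, only one measured step connects them: a 29-fold lower number from compound 1 to compound 2 (1.46 log units; beyond the scatter). It is large, lies beyond the scatter, and accompanies cyano in place of hydrogen on an aromatic carbon.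

Compound 3 `CC/C(=C(/c1ccc(/C=C/C(=O)O)cc1)c1ccc2[nH]ncc2c1)c1ccccc1C` keeps the rest of compound 2 and alters one group: methyl in place of cyano on an aromatic carbon. This is methyl in place of cyano on an aromatic carbon, ortho to a large group.

Among the compounds with values here, the single measured step bears on this change only in part. Within the data shown here, compound 3 loses the cyano group, but it does not regain the hydrogen of compound 1, and no measured compound shows what methyl does at this place. A substantial recovery toward compound 1, which stands at 5800 ng.h/mL, is therefore expected, though probably not a complete one. The expected change is a rise beyond the scatter, a 10-fold higher number from compound 2 to compound 3 (1.00 log units; beyond the scatter). For compound 3 the estimate is 2000 ng.h/mL, with an expected range of 500 ng.h/mL to 7000 ng.h/mL.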

Compound 3, area under the concentration-time curve: 7200 ng.h/mL
Compound 3: the middle estimate sits 3.6-fold (0.56 log units) below what was measured; measured number above the stated range.
By their numbers in this assay, from the lowest: compound 2; then compounds 1 and 3 (each within the scatter of the next).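

In this assay, the low number belongs to the cyano group alone and does not extend to a second substituent at this place: methyl in place of cyano brings a large rise (a 36-fold higher number from compound 2 to compound 3 (1.56 log units; beyond the scatter)). The other step, methyl in place of hydrogen on the same aromatic carbon, lies within the scatter (a 1.2-fold higher number from compound 1 to compound 3 (0.09 log units; within the scatter)), so this place carries a methyl group with no measurable cost, and the large fall that the earlier step recorded for the cyano group is specific to that group among the three compounds. Nothing measured here explains why the two groups part so widely in this read-out.

The compounds shown leave open whether other groups at this place, such as fluorine, chlorine, methoxy, an amine or a longer chain like ethyl, would stay with methyl and hydrogen or fall with cyano. They also leave open whether the same exchange of cyano for methyl would give a step of this size at another place on this ring, or with the carboxylic acid of the shared core replaced by an amide.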